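Swapping Dichlorophenyl for Difluorophenyl on the Amide Nitrogen

This account rests on a few compounds, and the source may have more. Where it says the series, first, only, none or still open, it means among the compounds named here.

Going by the values given here, in an in vitro ADME assay on microsomes from liver (Homo sapiens) for pharmacokinetics, read by LC-MS, with a stated time of 10 min, tested at 1 uM (on this read-out higher numbers stand for fast clearance and lower numbers for slow clearance), compound 1 (`COc1cccc(NC(=O)[C@H]2CN(C)C[C@@H]2c2ccc(/C=C/C(=O)Nc3ccccc3N)cc2)c1`) gives 14 mL/min/kg and compound 2 (`CN1C[C@H](C(=O)Nc2ccc(Cl)c(Cl)c2)[C@@H](c2ccc(/C=C/C(=O)Nc3ccccc3N)cc2)C1`) gives 14 mL/min/kg as well, so compound 2 stands level with its only measured neighbour. Compound 3 (`CN1C[C@H](C(=O)Nc2ccc(F)cc2F)[C@@H](c2ccc(/C=C/C(=O)Nc3ccccc3N)cc2)C1`) carries 2,4-difluorophenyl in place of 3,4-dichlorophenyl on an amide-type nitrogen. Among the compounds with values here, one measured step bears on this place: 3,4-dichlorophenyl in place of 3-methoxyphenyl on the same kind of nitrogen gave no change at the digits printed from compound 1 to compound 2 (within the scatter) in the clearance read-out. That is a single step, and no fluorinated phenyl group has been measured yet. On that evidence the expected outcome is no change at the digits printed from compound 2 to compound 3 (within the scatter) in this assay with no step beyond the scatter expected and no direction favoured. The estimated clearance of compound 3 is 14 mL/min/kg (expected range 8 mL/min/kg to 24 mL/min/kg) for now.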

Compound 3, clearance: 12 mL/min/kg
Beside the measured number, compound 3's estimate is 1.2-fold (0.07 log units) above it; the measured number falls inside the stated range.
By their numbers in this assay, from the lowest: compounds 3, 1 and 2 (each within the scatter of the next).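

In this assay the amide-type nitrogen now has a fluorinated phenyl group on record: 2,4-difluorophenyl in place of 3,4-dichlorophenyl gives a 1.2-fold lower number from compound 2 to compound 3 (0.07 log units; within the scatter) and in place of 3-methoxyphenyl gives a 1.2-fold lower number from compound 1 to compound 3 (0.07 log units; within the scatter). The three groups tried on this nitrogen, 3-methoxyphenyl, 3,4-dichlorophenyl and 2,4-difluorophenyl, thus all lie within the scatter of one another, so the earlier flat step was not confined to that one pair. Nothing available explains this result.

As far as these compounds go, all three groups are substituted phenyl rings, so it remains open how this assay would respond to a chain ending in an amine or a carboxylic acid at this nitrogen. These steps also leave open how changes elsewhere on the shared core would read.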